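Changing the Carbamate Alkyl Group: Compound 3 to Compound 4

The compounds below may be only part of what the source reports. "The series", "measured", "known", "first", "only" and "open" are said of these compounds alone.

Three compounds have been measured in a functional assay on WI-38 VA13 cells (Homo sapiens) for cytotoxicity; a lower number here means that less compound is needed, a higher number that more compound is needed for the effect:

compound 1 `O=C(Nc1ccc2nc(NC(=O)C3CCCCC3)sc2c1)c1c(Cl)cccc1Cl`: 0.015 ug/mL
compound 2 `O=C(O)CCC(=O)Nc1nc2ccc(NC(=O)c3c(Cl)cccc3Cl)cc2s1`: a limit of the assay, > 6.6 ug/mL
compound 3 `CC(C)OC(=O)Nc1nc2ccc(NC(=O)c3c(Cl)cccc3Cl)cc2s1`: 0.0026 ug/mL

Compound 3 has the lowest of the two real numbers in this assay. The nearest is compound 1, and the step of a 5.8-fold lower number from compound 1 to compound 3 (0.76 log units; beyond the scatter) is beyond the scatter. For compound 2 only a limit was reported (the limit of > 6.6 ug/mL in this assay, at which 1 of the 3 values shown sits), so the steps of an at least 440-fold higher number from compound 1 to compound 2 (2.64 log units; beyond the scatter) and an at least 2500-fold lower number from compound 2 to compound 3 (3.40 log units; beyond the scatter) are both large and open-ended.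

Compound 4 `COCCOC(=O)Nc1nc2ccc(NC(=O)c3c(Cl)cccc3Cl)cc2s1` differs from compound 3 in one place: 2-methoxyethyl in place of isopropyl on an oxygen next to a carbonyl group. All three measured steps changed the whole group on the carbonyl carbon, and the large ones involved the charged 2-carboxyethyl group. For the measured compounds named here, the new change keeps the carbamate and only swaps one uncharged alkyl group for another, so none of the measured steps matches it closely. The most comparable step, a 5.8-fold lower number from compound 1 to compound 3 (0.76 log units; beyond the scatter), was modest. A small step in this assay is therefore expected, with a 1.9-fold higher number from compound 3 to compound 4 (0.28 log units; within the scatter) likely within the scatter or slightly upward. Compound 4 is estimated at 0.005 ug/mL, with a range from 0.0015 ug/mL to 0.02 ug/mL.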

Compound 4, half-maximal effective concentration: 0.011 ug/mL
Estimate against measurement, compound 4: 2.2-fold (0.34 log units) below; measured number inside the range.
By their numbers in this assay, from the lowest: compound 3; then compounds 4 and 1 (each within the scatter of the next). At a limit, above all of these: compound 2.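

Moving from isopropyl to 2-methoxyethyl on the carbamate oxygen, a swap between two groups with no net charge, gives a modest but real shift in this assay: a 4.2-fold higher number from compound 3 to compound 4 (0.63 log units; beyond the scatter). The low number of compound 3 is therefore not shared by every carbamate here, since compound 4 goes against any such pattern: a 1.4-fold lower number from compound 1 to compound 4 (0.13 log units; within the scatter), so the 2-methoxyethoxy group and the cyclohexyl group on the carbonyl carbon cannot be told apart in this assay. The added oxygen does not bring the number anywhere near that of the acid-bearing compound 2, yet the step of an at least 600-fold lower number from compound 2 to compound 4 (2.77 log units; beyond the scatter) remains large and open-ended, with the value of compound 2 being a limit of the assay and not a number: the limit of > 6.6 ug/mL in this assay, at which 1 of the 4 values shown sits.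

The 2-methoxyethyl group differs from isopropyl both in chain shape and in carrying an oxygen, so these two compounds cannot show which of the two differences goes with the shift. A plain propyl or butyl chain on the same oxygen would separate them, while a 2-aminoethyl group would show how an amine at this place compares.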